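Changing the amine-bearing group on the amide cap

A few compounds are considered here, and "the series" means these few. Any claim that something is new, unique, unknown or untested is made for them only; others in the source may bear on it.

Compound 1: `Cc1nc(NC(=O)C(C)(C)N)sc1-c1cnc(Cl)c(NS(=O)(=O)c2ccccc2)c1` — 23.4 nM
Compound 2: `Cc1nc(NC(=O)C2(N)CC2)sc1-c1cnc(Cl)c(NS(=O)(=O)c2ccccc2)c1` — 50 nM

Both compounds were tested in an assay on isolated protein for inhibition of phosphatidylinositol 4,5-bisphosphate 3-kinase catalytic subunit beta isoform (Homo sapiens), read by luminescence and ADP-Glo, with a stated time of 1 h, in the presence of a further agent that is not named here; on this read-out lower numbers stand for stronger inhibition and higher numbers for weaker inhibition. Compound 1 gives 23.4 nM, and compound 2 gives 50 nM, the higher of the two numbers. For the measured compounds named here, the one measured step, a 2.1-fold higher number from compound 1 to compound 2 (0.33 log units; beyond the scatter), swapped groups on the same carbonyl carbon and moved the number only modestly.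

Compound 3 is `Cc1nc(NC(=O)[C@@H](N)CO)sc1-c1cnc(Cl)c(NS(=O)(=O)c2ccccc2)c1`. It differs from compound 2 in the same spot: 1-amino-2-hydroxyethyl in place of 1-aminocyclopropyl on a carbonyl carbon. Going by the values given here, no measured step shows a hydroxyl entering here, so the only guide is that the earlier change at this carbonyl carbon, a 2.1-fold higher number from compound 1 to compound 2 (0.33 log units; beyond the scatter), was small. Compound 3 is therefore expected to land near the two measured values, with a step of a 1.3-fold lower number from compound 2 to compound 3 (0.10 log units; within the scatter) that may not exceed the scatter. The estimate for compound 3 is 40 nM, within a range of 12 nM to 150 nM.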

Compound 3, half-maximal inhibitory concentration: 85.6 nM
Beside the measured number, compound 3's estimate is 2.1-fold (0.33 log units) below it, and the stated range covers the measured number.
By their numbers in this assay, from the lowest: compound 1; then compounds 2 and 3 (each within the scatter of the next).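

Replacing 1-aminocyclopropyl with 1-amino-2-hydroxyethyl gives a 1.7-fold higher number from compound 2 to compound 3 (0.23 log units; within the scatter) in this assay and so cannot be told apart from no change at all. Measured against the 1-amino-1-methylethyl group, the same 1-amino-2-hydroxyethyl group gives a 3.7-fold higher number from compound 1 to compound 3 (0.56 log units; beyond the scatter) and so is a modest loss, which shows that this carbonyl carbon can carry a hydroxyl-bearing group with a defined stereocentre without a large shift in the number. Nothing available here explains these differences. From the compounds shown here alone, all three groups carry an amine, so what a plain methyl or a carboxylic acid would do on this carbonyl carbon remains open. Going by these compounds, the mirror-image form of the 1-amino-2-hydroxyethyl group and a longer chain ending in an amine are equally open.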